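Sulfonamide nitrogen substitution in a thiourea sulfonamide pair

The source may report more compounds than this note shows. Statements on the series, on what has been measured and on what is new or still open speak of the compounds shown alone.

Of the compounds shown here, two have numbers so far. Compound 1 `O=C(Nc1ccccc1)Nc1ccc(S(=O)(=O)Nc2ccnc3cc(C(F)(F)F)ccc23)cc1` gives 30200 nM in a functional assay on LoVo cells (Homo sapiens) for antiproliferative activity, read by sulforhodamine B assay, with a stated time of 48 h; a lower number here means a stronger inhibitor, a higher number a weaker inhibitor. Compound 2 `NS(=O)(=O)c1ccc(N/C(S)=N\c2ccnc3cc(C(F)(F)F)ccc23)cc1` gives 34500 nM in this assay; the two values lie within the scatter of each other, so neither stands apart. Compound 3 `Cc1noc(NS(=O)(=O)c2ccc(N/C(S)=N\c3ccnc4cc(C(F)(F)F)ccc34)cc2)c1C` differs from compound 2 by 3,4-dimethyl-1,2-oxazol-5-yl in place of hydrogen on a sulfonamide nitrogen. Among the measured compounds shown here, no step between measured compounds is available to set the size of this change. The step from compound 2 to compound 3 in this assay is expected to be small, a 1.4-fold lower number from compound 2 to compound 3 (0.14 log units; within the scatter), at most a modest move toward a lower number. Compound 3 is estimated at 25000 nM, with a range from 8000 nM to 80000 nM.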

Compound 3, half-maximal inhibitory concentration: 67100 nM
Compound 3: middle estimate off by 2.7-fold (0.43 log units), on the low side; low and high end bracket the measured number.
By their numbers in this assay, from the lowest: compounds 1, 2 and 3 (each within the scatter of the next, the first and the last beyond it).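

In this assay the first step read at this position is a 1.9-fold higher number from compound 2 to compound 3 (0.29 log units; within the scatter) and so cannot be told apart from repeat measurement. Replacing hydrogen on the sulfonamide nitrogen with 3,4-dimethyl-1,2-oxazol-5-yl adds 7 heavy atoms and one five-membered aromatic ring without a move beyond the scatter. No evidence on hand bears on this result.

Going by these compounds, whether a methyl group, an acetyl group or a phenyl ring carrying a carboxylic acid on this nitrogen would read differently remains open. One step sets no trend for the position.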